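Working notes: methyl in place of chloro, compound 3

A few compounds are considered here, and "the series" means these few. Any claim that something is new, unique, unknown or untested is made for them only; others in the source may bear on it.

- compound 1 `Cc1ccc2nc(NC(c3cn(-c4ccccc4)nc3-c3cccc(Cl)c3)c3c(O)ccc4ccccc34)sc2c1` gives 49700 nM in the first test
- compound 2 `O=[N+]([O-])c1ccc(-c2nn(-c3ccccc3)cc2C(Nc2nc3ccc(Cl)cc3s2)c2c(O)ccc3ccccc23)cc1` gives 38600 nM in the same test

In a functional assay on MCF7 cells (Homo sapiens) for antiproliferative activity, read by MTT assay, with a stated time of 48 h (on this read-out lower numbers stand for stronger inhibition and higher numbers for weaker inhibition), compound 2 stands within the scatter of compound 1, so these two values set no order. Compound 3 (`Cc1ccc2nc(NC(c3cn(-c4ccccc4)nc3-c3ccc([N+](=O)[O-])cc3)c3c(O)ccc4ccccc34)sc2c1`) is not yet measured. It differs from compound 2 by methyl in place of chloro on an aromatic carbon, with methyl in place of chloro on an aromatic carbon. For the measured compounds named here, no measured step covers this change. Going by the values given here, with only two close values to go on, no step beyond the scatter is expected in this assay here. The estimated step is a 1.1-fold higher number from compound 2 to compound 3 (0.04 log units; within the scatter) and stays within the scatter. For compound 3 the estimated value is 42000 nM, with an expected range of 20000 nM to 85000 nM overall.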

Compound 3, half-maximal inhibitory concentration: 20700 nM
Compound 3: middle estimate off by 2.0-fold (0.31 log units), on the high side, and the stated range covers the measured number.
By their numbers in this assay, from the lowest: compounds 3, 2 and 1 (each within the scatter of the next, the first and the last beyond it).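

Notes on the 6-position: in this assay 6-methyl-1,3-benzothiazol-2-yl in place of 6-chloro-1,3-benzothiazol-2-yl gives a 1.9-fold lower number from compound 2 to compound 3 (0.27 log units; within the scatter) and so sets no order between these two groups. For the compounds shown here, with the 6-methyl group held, 4-nitrophenyl in place of 3-chlorophenyl gives a 2.4-fold lower number from compound 1 to compound 3 (0.38 log units; beyond the scatter) and is the first step beyond the scatter, placing the larger difference at the aryl group rather than the 6-position. No measured evidence bears on either step.

From the compounds shown here alone, whether an amine or a methoxy group at the 6-position would move the number beyond the scatter remains open. Also open, going by these compounds, is whether the aryl step holds with the 6-chloro group in place.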